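Swapping a Methyl for a Cyclopropyl on the Aryl Ring

The source may hold more compounds than are shown below. What is called first, only, known or untested is meant among the compounds shown, and "the series" means these compounds.

Measured compounds:
compound 1, `Cc1cc(OCc2cccc(F)c2)ccc1CN[C@@H](C)C(N)=O`, in an assay on Sf9 cells for inhibition of Amine oxidase [flavin-containing] B (Homo sapiens), with stated times of 15 min and 60 min (a higher number here means a weaker inhibitor, a lower number a stronger inhibitor), gives 69 nM.
compound 2, `C#CCN(C)C(=O)[C@H](C)NCc1ccc(OCc2cccc(F)c2)cc1`, in this assay gives > 10000 nM, which is a limit of the assay and not a number.

Among the compounds with values here, compound 1 holds the only actual number in this assay; the other value shown is a limit, (the limit of > 10000 nM in this assay, at which 1 of the 2 values shown sits). Compound 3, `C[C@H](NCc1ccc(OCc2cccc(F)c2)cc1C1CC1)C(N)=O`, has not yet been measured. It differs from compound 1 in one place: cyclopropyl in place of methyl on an aromatic carbon. Both compounds keep the same core and the same amide side chain. As far as these compounds go, the cyclopropyl brings a small ring where a single carbon stood, and the effect of that exchange in this assay is unknown; the expected step of a 2.2-fold higher number from compound 1 to compound 3 (0.34 log units; beyond the scatter) is small, leaning toward a weaker inhibitor, and may well sit within the usual scatter. Compound 3 is therefore expected to give about 150 nM, in a range from 40 nM to 600 nM.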

Compound 3, half-maximal inhibitory concentration: 1660 nM
Compound 3: the middle estimate sits 11-fold (1.04 log units) below what was measured; the measured number lies above the stated range.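

In this assay, within the data shown here, the aromatic carbon ortho to the ((1-carbamoylethyl)amino)methyl group proves sensitive to what it carries, a point no earlier pair could show: replacing methyl with cyclopropyl gives a 24-fold higher number from compound 1 to compound 3 (1.38 log units; beyond the scatter). The exchange is modest when counted, with 3 heavy atoms entering where 1 leaves, and neither group has a hydrogen-bond donor or acceptor. No measured property shown here accounts for this loss of inhibition.

The compounds shown leave open how an ethyl group or a chlorine atom on this same aromatic carbon would fare, and so whether the ring itself matters or the added carbons alone. The value of compound 2, > 10000 nM, is a limit of the assay, and that compound differs from compound 1 in more than one place, so it cannot settle this.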